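This account rests on a few compounds, and the source may have more. Where it says the series, first, only, none or still open, it means among the compounds named here.

In a functional assay on K562 cells (Homo sapiens) for cytotoxicity, read by MTT assay, with a stated time of 5 days (on this read-out lower numbers stand for stronger inhibition and higher numbers for weaker inhibition), compound 1 (`COc1ccc(-c2cn(-c3cc(OC)c(OC)c(OC)c3)nn2)cc1O`) gives > 10000 nM as a limit of the assay, not a number. Compound 2 (`COc1ccc(Cn2cc(-c3cc(OC)c(OC)c(OC)c3)nn2)cc1`) reads > 10000 nM and this too is only a limit. Compound 3 (`COc1ccc(Cn2cc(-c3cc(OC)c(OC)c(OC)c3)nn2)cc1Br`) differs from compound 2 by one change (bromo in place of hydrogen on an aromatic carbon) that turns 4-methoxyphenyl into 3-bromo-4-methoxyphenyl. Within the data shown here, no measured pair shows what this change does, so in this assay only a modest shift towards stronger inhibition is expected, and another limit is quite possible. The expected shift is an at least 1.6-fold lower number from compound 2 to compound 3 (0.22 log units; that floor lies within the scatter) at most a small one. For compound 3 the estimated value is 6000 nM with an expected range of 800 nM to 10000 nM in this estimate.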

Compound 3, half-maximal inhibitory concentration: > 10000 nM
Compound 3 was reported as a limit; the forecaster's own chance of this, stated with the estimate: 55%; middle value at least 1.6-fold (0.22 log units) from the limit.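

Compound 2 and compound 3 both sit at a limit of the assay, so no step can be read between them: the limit of > 10000 nM in this assay, at which 3 of the 3 values shown sit. The compounds shown leave open what bromo in place of hydrogen does in this assay.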